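Notes on compound 3: aryl exchange at the five-membered ring

A few compounds are considered here, and "the series" means these few. Any claim that something is new, unique, unknown or untested is made for them only; others in the source may bear on it.

Measured compounds:
Compound 1, `CCCCCCCCc1ccc(OCC(=O)Cn2nnc(SC)n2)cc1`, in an assay on microsomes from brain for inhibition of Fatty-acid amide hydrolase 1 (Rattus norvegicus), read by fluorescence and HPLC, with a stated time of 60 min; on this read-out higher numbers stand for weaker inhibition and lower numbers for stronger inhibition: 31 nM
Compound 2, `CCCCCCCCc1ccc(OCC(=O)Cn2nnc(-c3ccc(C(=O)OC)cc3)n2)cc1`, in this assay: 29 nM

On the numbers shown, compound 2 carries the lowest of the two values in this assay, its only neighbour being compound 1; the step of a 1.1-fold lower number from compound 1 to compound 2 (0.03 log units; within the scatter) is within the scatter, so the two compounds cannot be ordered against each other.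

Compound 3, `CCCCCCCCc1ccc(OCC(=O)Cn2nnc(-c3cccc(S(=O)(=O)N(C)C)c3)n2)cc1`, is the next member. It differs from compound 2 in one place: 3-(dimethylsulfamoyl)phenyl in place of 4-(methoxycarbonyl)phenyl on an aromatic carbon.

Going by the values given here, only one measured step touches this position, a 1.1-fold lower number from compound 1 to compound 2 (0.03 log units; within the scatter), which exchanged methylsulfanyl for 4-(methoxycarbonyl)phenyl and left the number where it was. That step swapped a small group for an aryl; the present change swaps one aryl for another carrying a different substituent, so the precedent bears on it only loosely. No measured step gives a reason to expect a move beyond the scatter in this assay in either direction.

Compound 3 is therefore expected to give about 35 nM, in the range 12 nM to 100 nM; the step of a 1.2-fold higher number from compound 2 to compound 3 (0.08 log units; within the scatter) is the estimate, not a measurement.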

Compound 3, half-maximal inhibitory concentration: 420 nM
The estimate for compound 3 lay 12-fold (1.08 log units) below the measured number; measured number above the stated range.
By their numbers in this assay, from the lowest: compounds 2 and 1 (each within the scatter of the next); then compound 3.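

In this assay, the carbon of the five-membered aromatic ring with 4 nitrogen does not tolerate every aryl group: replacing 4-(methoxycarbonyl)phenyl with 3-(dimethylsulfamoyl)phenyl gives a 14-fold higher number from compound 2 to compound 3 (1.16 log units; beyond the scatter), whereas the earlier exchange at this carbon gave only a 1.1-fold lower number from compound 1 to compound 2 (0.03 log units; within the scatter). Replacing methylsulfanyl with the same 3-(dimethylsulfamoyl)phenyl gives a 14-fold higher number from compound 1 to compound 3 (1.13 log units; beyond the scatter), so both routes to compound 3 end in a large rise, and an aryl group at this carbon does not by itself keep the number low. Nothing available here bears on the reason for this rise.

The exchange alters both the substituent on the phenyl ring and the number in its name, so these compounds leave open whether the step goes with the dimethylsulfamoyl group or with its 3-placement, a question that 4-(dimethylsulfamoyl)phenyl and 3-(methoxycarbonyl)phenyl would separate. They also leave open how a phenyl ring carrying a carboxylic acid or an amine would read in this assay.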